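A Trifluoromethyl Added to an Inactive Triazole Core

The source may hold more compounds than are shown below. What is called first, only, known or untested is meant among the compounds shown, and "the series" means these compounds.

Compound 1, with structure `Cc1c(O)ccc2c1[C@H](Cn1cc(-c3ccccc3)nn1)[C@@]13CC(=O)[C@@](C)(CC[C@@H]21)C3`, carries a plain phenyl on its triazole arm. In a functional assay on SW480 cells (Homo sapiens) for cytotoxicity, read by MTT assay, with a stated time of 4 days (on this read-out lower numbers stand for stronger inhibition and higher numbers for weaker inhibition), compound 1 gives only a limit, > 20000 nM, not a measured number. Compound 2, `C=C1C[C@]23C[C@@]1(O)CC[C@@H]2c1cccc(C)c1[C@@H]3Cn1cc(-c2ccc(Cl)cc2)nn1`, sits at the same limit in this assay, > 20000 nM. Among the compounds with values here, compound 3, `C=C1C(=O)[C@]23C[C@@]1(O)CC[C@H]2c1ccc(OS(=O)(=O)c2ccc(C)cc2)c(C)c1[C@@H]3Cn1cc(-c2ccc(C)cc2)nn1`, is the one member of this set with a measured value, giving 1460 nM in this assay. Compound 1 therefore stands at the weak end of what is shown, at the limit of > 20000 nM in this assay, at which 2 of the 3 values shown sit.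

Compound 4, `Cc1c(O)ccc2c1[C@H](Cn1cc(-c3ccc(C(F)(F)F)cc3)nn1)[C@@]13CC(=O)[C@@](C)(CC[C@@H]21)C3`, differs from compound 1 by trifluoromethyl in place of hydrogen on an aromatic carbon. Within the data shown here, no pair of measured compounds shows this change, so its effect in this assay is not known from the data. Given that compound 1 shows only a limit, > 20000 nM, compound 4 is expected to remain weak, with the step from compound 1 to compound 4 estimated as a step that the limit leaves unreadable from compound 1 to compound 4, hardly beyond the scatter. Compound 4 is expected to give about 25000 nM in this assay, within a range from 5000 nM to 100000 nM.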

Compound 4, half-maximal inhibitory concentration: > 20000 nM
Compound 4: a limit, no number; the forecaster's own chance of this, stated with the estimate: 70%; the middle value is on the limit's open side.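

Within the data shown here, compound 1 and compound 4 each give only a limit in this assay, not a number, and no step between them can be read. The compounds shown leave open whether trifluoromethyl in place of hydrogen on an aromatic carbon changes the activity of this core at all.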